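A Second Chloro Group Added to the Ring of Compound 1

The source may report more compounds than this note shows. Statements on the series, on what has been measured and on what is new or still open speak of the compounds shown alone.

Of the compounds shown here, three have so far been measured in a physicochemical assay for lipophilicity, measured as octanol-water partition; a lower number here means a more polar compound, a higher number a more lipophilic compound. Compound 1 `OCC(O)COc1ccccc1Cl` gives 1.29, the lowest of the three numbers. Compound 3 `Cc1cccc(Cl)c1OCC(C)O` gives 2.73, which stands above compound 1 by more than the scatter, and compound 2 `Cc1cc(Cl)c(OCCCO)c(Cl)c1` gives 3.36, further above still. The account now follows the step from compound 1 to compound 4 `OCC(O)COc1ccc(Cl)cc1Cl`, which has not yet been measured in this assay. The change is chloro in place of hydrogen on an aromatic carbon. Among the compounds with values here, no step between two measured compounds isolates this change, so the expectation rests on the nature of the change alone. A rise beyond the scatter is expected, with a step of about a number 0.71 log units higher from compound 1 to compound 4 (beyond the scatter) estimated. For compound 4 a value of 2 is expected, within a range from 1.6 to 2.4.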

Compound 4, partition coefficient: 1.99
For compound 4 the middle estimate is 0.01 log units above the measured one; the range from low to high includes it.
By their numbers in this assay, from the lowest: compound 1; then compound 4; then compound 3; then compound 2.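

In this assay, within the data shown here, chloro in place of hydrogen on this aromatic carbon, meta to a chloro group and para to a group of 6 heavy atoms, gives a number 0.70 log units higher from compound 1 to compound 4 (beyond the scatter) and so provides the first step here that isolates one change. Nothing shown here explains the size of this step. As far as these compounds go, whether chloro would give a similar step on another aromatic carbon of the core of compound 1 remains open. So does the step that a bromo group or a methoxy group would give at this same position.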